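Removing the Ethoxy Group: An Estimate for Compound 4

This account rests on a few compounds, and the source may have more. Where it says the series, first, only, none or still open, it means among the compounds named here.

Compound 1 `Cc1ccc2nc(Nc3nc4ccccc4s3)sc2c1`: in a functional assay on B16-F10 cells (Mus musculus) for cytotoxicity, read by MTT assay, with a stated time of 48 h (a higher number here means a weaker inhibitor, a lower number a stronger inhibitor), compound 1 gives > 50000 nM, a limit of the assay.
Compound 2 `Clc1ccc2nc(Nc3nc4ccccc4s3)sc2c1`: in this assay compound 2 gives > 50000 nM, a limit of the assay.
Compound 3 `CCOc1ccc2nc(Nc3nc4ccccc4s3)sc2c1`: in this assay compound 3 gives > 50000 nM, a limit of the assay.

Compound 3 therefore stands only at a limit, with no number of its own. All three values sit at the limit of > 50000 nM in this assay, at which 3 of the 3 values shown sit. The change to compound 4 `c1ccc2sc(Nc3nc4ccccc4s3)nc2c1` is hydrogen in place of ethoxy on an aromatic carbon. The steps a step that the two limits leave unreadable from compound 1 to compound 2, a step that the two limits leave unreadable from compound 1 to compound 3 and a step that the two limits leave unreadable from compound 2 to compound 3 cannot be read, so they give no direction and no size to expect. The step that the limit leaves unreadable from compound 3 to compound 4 is expected to be nothing visible. Compound 4 is expected to give 60000 nM, with a range from 20000 nM to 200000 nM.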

Compound 4, half-maximal inhibitory concentration: > 50000 nM
Compound 4: no number, only a limit; the forecaster's own chance of this, stated with the estimate: 80%; the middle value lies beyond the limit too.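

Compound 4 gives > 50000 nM in this assay, which is a limit and not a number. Its steps from compound 1, compound 2 and compound 3 therefore cannot be read: the limit of > 50000 nM in this assay, at which 4 of the 4 values shown sit.

From the compounds shown here alone, how strongly any of these four compounds acts, and whether swapping the group on the shared core changes that, stays open.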